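This account rests on a few compounds, and the source may have more. Where it says the series, first, only, none or still open, it means among the compounds named here.

Compound 1 `CN[C@@H]1CCN(c2cc3c(cc2F)c(=O)c(C(=O)O)cn3Cc2ccc(-c3ccccc3)cc2)C1` gives 34800 nM in an assay on isolated protein for inhibition of DNA topoisomerase 1 (Homo sapiens), with a stated time of 15 min; a higher number here means a weaker inhibitor, a lower number a stronger inhibitor. Compound 2 `CN[C@@H]1CCN(c2c(F)cc3c(=O)c(C(=O)O)cn(Cc4ccc(-c5ccccc5)cc4)c3c2OC)C1` gives 57700 nM. Compound 3 `COc1c(N2CC[C@@H](N)C2)c(F)cc2c(=O)c(C(=O)O)cn(Cc3ccc(-c4ccc(F)cc4)cc3)c12` gives 58600 nM.

Among these three numbers compound 1 carries the lowest one, yet compound 2 and compound 3 both sit within the scatter of it, so no order can be read among them. Going by the values given here, the single measured step, a 1.7-fold higher number from compound 1 to compound 2 (0.22 log units; within the scatter), concerns a methoxy group on the core and stays within the scatter. Compound 4 `CNC[C@@H]1CCN(c2cc3c(cc2F)c(=O)c(C(=O)O)cn3Cc2ccc(-c3ccccc3)cc2)C1` differs from compound 1 by (methylamino)methyl in place of methylamino on a saturated ring carbon. Among the compounds with values here, no measured step touches this saturated ring carbon, so the account has nothing to lean on beyond the value of compound 1 itself. The expectation for compound 4 is therefore a 1.0-fold higher number from compound 1 to compound 4 (0.00 log units; within the scatter), a number close to that of compound 1, estimated at 35000 nM with a range from 12000 nM to 100000 nM.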

Compound 4, half-maximal inhibitory concentration: 168000 nM
Estimate against measurement, compound 4: 4.8-fold (0.68 log units) below; measured number outside the range, above it.
By their numbers in this assay, from the lowest: compounds 1, 2 and 3 (each within the scatter of the next); then compound 4.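

Going by these compounds alone, the step of a 4.8-fold higher number from compound 1 to compound 4 (0.68 log units; beyond the scatter) is the first in this assay to lie beyond the scatter, which the methoxy step on the core did not do. It shows that this saturated ring carbon is sensitive to what it carries: moving from methylamino to (methylamino)methyl gives a modestly weaker inhibitor. Nothing available gives a reason for this step.

As far as these compounds go, whether a longer chain such as an aminoethyl group, or a hydroxymethyl group, would behave alike at this ring carbon stays open. So does whether the step would have the same size on the methoxy-bearing core of compound 2.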